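The source may report more compounds than this note shows. Statements on the series, on what has been measured and on what is new or still open speak of the compounds shown alone.

Measured compounds and their values in a functional assay for antagonist activity at Oxoeicosanoid receptor 1 (Homo sapiens), read by fluorescence and calcium flux, with stated times of 2 min and 1 min; a lower number here means a stronger inhibitor, a higher number a weaker inhibitor:

Compound 1 `C[C@H](CC(=O)O)CC(=O)c1c(CCCCCCc2ccccc2)n(C)c2ccc(Cl)cc12` gives 0.12 nM.
Compound 2 `CC(CC(=O)O)CC(=O)n1c(CCCCCc2ccccc2)cc2ccc(Cl)cc21` gives 2.1 nM.
Compound 3 `CC(CC(=O)O)CC(=O)c1c(CCCCCC(F)(F)F)n(C)c2ccc(Cl)cc12` gives 38 nM.

Compound 2 holds the second highest of the three numbers in this assay. Its nearest neighbour on the numbers is compound 1, whose value lies well beyond the scatter on the lower side; compound 3 lies equally far beyond the scatter on the higher side. Going by the values given here, none of these three pairs differs in a single place, so no step between measured compounds can be read off: compound 1 and compound 3 differ from compound 2 in the acyl attachment, in the methyl on the ring nitrogen and in the chain end at once, and what their values show is only that the series spans a wide window of potencies.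

Compound 4 `CC(CC(=O)O)CC(=O)n1c(CCCCc2ccccc2)cc2ccc(Cl)cc21` is the unmeasured member. It differs from compound 2 by one change: phenyl in place of benzyl on a saturated chain carbon, four bonds along the chain from an aromatic carbon. With no single-point comparison available, the size of this step in this assay is not anchored by any measured pair. Shortening the chain by one unit is expected to cost a little rather than gain, with a step of about a 1.9-fold higher number from compound 2 to compound 4 (0.28 log units; within the scatter) expected, close to or just beyond the scatter. Compound 4 is therefore estimated at 4 nM, within a range of 1.2 nM to 14 nM.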

Compound 4, half-maximal inhibitory concentration: 18 nM
Beside the measured number, compound 4's estimate is 4.5-fold (0.65 log units) below it; measured number above the stated range.
By their numbers in this assay, from the lowest: compound 1; then compound 2; then compound 4; then compound 3.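

In this assay, going by these compounds alone, the first single-place comparison is an 8.6-fold higher number from compound 2 to compound 4 (0.93 log units; beyond the scatter), so the window of potencies seen earlier can now be tied, at least in part, to one specific change. Phenyl in place of benzyl on a saturated chain carbon, four bonds along the chain from an aromatic carbon, leaves the aromatic ring, the hydrogen-bond donors and acceptors and the net charge of the group as they were, yet the step still lies beyond the scatter, so chain length at this place matters for this read-out and the chain cannot be shortened without cost. Nothing at hand accounts for the size of this step.

Going by these compounds, whether a longer chain at this place on the core of compound 2 would continue the trend or reverse it stays open, and one pair cannot show where the best length lies. Also open, on these data alone, are an ether oxygen within the chain, a pyridine ring at its end, and whether the same shortening carries the same cost on the core of compound 1.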